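The source may report more compounds than this note shows. Statements on the series, on what has been measured and on what is new or still open speak of the compounds shown alone.

Working notes on the series. Compound 1 `Cc1cnc(NC(=O)NCCOc2ccc(Cl)c(C)c2)s1` gives 1600 nM in a physicochemical assay for solubility, read by nephelometry, at pH 2; a higher number here means a more soluble compound, a lower number a less soluble compound. Compound 2 `CC(C)c1cnc(NC(=O)CCCOc2ccccc2)s1` is reported in this assay only as a limit, < 1200 nM, and on the numbers shown compound 2 sits at the limit of < 1200 nM in this assay, at which 1 of the 2 values shown sits. Compound 3 `O=C(CCCOc1ccccc1)Nc1ncc(Cl)s1` is not yet measured; it differs from compound 2 in one place, (chloro in place of isopropyl on an aromatic carbon). Going by the values given here, no measured step covers this change, so the direction rests on the structures alone. The step is expected to be a small rise of an at least 1.3-fold higher number from compound 2 to compound 3 (0.12 log units; that floor lies within the scatter) in this assay, possibly within the scatter. Compound 3 is estimated at 1600 nM, in the range 600 nM to 4500 nM.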

Compound 3, solubility: < 1200 nM
Compound 3: a limit, no number; the forecaster's own chance of this, stated with the estimate: 40%; middle value at least 1.3-fold (0.12 log units) from the limit.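

Compound 2 and compound 3 are both reported only as limits, so no step can be read between them: the limit of < 1200 nM in this assay, at which 2 of the 3 values shown sit.

The compounds shown leave open whether chloro in place of isopropyl on an aromatic carbon changes the read-out in this assay at all.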